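Fluoro in place of hydrogen on the shared core

The source may hold more compounds than are shown below. What is called first, only, known or untested is meant among the compounds shown, and "the series" means these compounds.

Compound 1 `CC(C)(O)c1cncc(-n2ncc3ccccc32)c1`: 535 nM
Compound 2 `Cc1nn(-c2cncc(C(C)(C)O)c2)c2ccccc12`: 779 nM
Compound 3 `CC(C)(O)c1cncc(-n2nc(C3CC3)c3ccccc32)c1`: > 8300 nM

In an ADME assay on cells for inhibition of cytochrome P450 11B1, mitochondrial (Homo sapiens), read by HTRF, with stated times of 1 h and 3 h (on this read-out lower numbers stand for stronger inhibition and higher numbers for weaker inhibition), compound 1 gives 535 nM, the lowest of the two numbers shown. Compound 2 gives 779 nM, so that the step is a 1.5-fold higher number from compound 1 to compound 2 (0.16 log units; within the scatter). For compound 3 the assay reports only a limit, > 8300 nM (the limit of > 8300 nM in this assay, at which 1 of the 3 values shown sits). The steps to it are an at least 15-fold higher number from compound 1 to compound 3 (1.19 log units; beyond the scatter) and an at least 10-fold higher number from compound 2 to compound 3 (1.02 log units; beyond the scatter).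

Compound 4 `CC(C)(O)c1cncc(-n2ncc3c(F)cccc32)c1` differs from compound 1 by fluoro in place of hydrogen on an aromatic carbon. The measured steps each exchange a hydrogen on an aromatic carbon of the core for a carbon group: methyl leaves the number within the scatter, cyclopropyl pushes it past the limit. Fluoro brings a single heavy atom and no ring, and it enters on a different carbon of the core than those groups, so the cyclopropyl step is a weak guide and the methyl step the nearer one. Compound 4 is therefore expected to stay close to compound 1, with an estimated 500 nM between 200 nM and 1300 nM, that is a 1.1-fold lower number from compound 1 to compound 4 (0.03 log units; within the scatter), a step not expected to exceed the scatter.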

Compound 4, half-maximal inhibitory concentration: 149 nM
The estimate for compound 4 lay 3.4-fold (0.53 log units) above the measured number; measured number below the stated range.
By their numbers in this assay, from the lowest: compound 4; then compounds 1 and 2 (each within the scatter of the next). At a limit, above all of these: compound 3.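

In this assay fluoro in place of hydrogen gives a 3.6-fold lower number from compound 1 to compound 4 (0.56 log units; beyond the scatter) and is the first change on the shared core shown here to lower the number beyond the scatter. The earlier changes, methyl and cyclopropyl on a different aromatic carbon, gave either a step within the scatter or a higher number, so this carbon of the six-membered aromatic ring of carbon only, ortho to a fused ring, is the first place shown where a new group brings a gain. Nothing measured here gives a reason for this step.

On these data alone, whether the gain belongs to fluoro itself or to any group on this carbon stays open, and chloro, methoxy, nitrile or an amine there would separate the two. Also open, as far as these compounds go, is how fluoro behaves on the other carbons of that ring, and whether it would combine with the methyl of compound 2.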